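Ester to fluoro on the benzoxazole-type core

The source may report more compounds than this note shows. Statements on the series, on what has been measured and on what is new or still open speak of the compounds shown alone.

Compound 1 `COc1cc(Cl)cc2nc(N3CCN(C)CC3)oc12` gives 6.16 in a functional assay on ileum (strain Hartley) for agonist activity at 5-hydroxytryptamine receptor 3A (Cavia porcellus); on this read-out lower numbers stand for lower potency and higher numbers for higher potency (the scale is a negative logarithm). Compound 3 `COc1cc(C)cc2nc(N3CCN(C)CC3)oc12` gives 6.13 in this assay, and the step of a number 0.03 log units lower from compound 1 to compound 3 (within the scatter) is methyl in place of chloro on an aromatic carbon. Compound 2 `CCOC(=O)c1ccc2oc(N3CCN(C)CC3)nc2c1` is reported in this assay only as a limit, < 4, so for compound 2 no number is known, as noted in the limit of < 4 in this assay, at which 1 of the 3 values shown sits. Compound 4 `CN1CCN(c2nc3cc(F)ccc3o2)CC1` is not yet measured in this assay.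

The step from compound 2 to compound 4 is fluoro in place of ethoxycarbonyl on an aromatic carbon. Within the data shown here, no measured step touches this position or this group: the only measured step, from compound 1 to compound 3, exchanges chloro for methyl elsewhere on the core and lies within the scatter. The measured numbers show that two small substituents on the core, together with methoxy, sit in the range of compound 1 and compound 3, whereas the ethoxycarbonyl compound 2 yields only a limit. The change to compound 4 removes the ethoxycarbonyl and leaves a single fluoro without methoxy.

Compound 4 is therefore expected to move in this assay by about a number at least 1.30 log units higher from compound 2 to compound 4 (beyond the scatter), upward from the limit of compound 2. The estimate for compound 4 is 5.3, with a range from 4 to 6.6.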

Compound 4, negative logarithm of the half-maximal effective concentration: 5.57
Beside the measured number, compound 4's estimate is 0.27 log units below it; the range from low to high includes it.
By their numbers in this assay, from the lowest: compound 4; then compounds 3 and 1 (each within the scatter of the next). At a limit, below all of these: compound 2.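

Exchange of ethoxycarbonyl for fluoro on this aromatic carbon gives a number at least 1.57 log units higher from compound 2 to compound 4 (beyond the scatter), the first step in the series that reaches beyond the scatter in this assay, whereas the only earlier step, a number 0.03 log units lower from compound 1 to compound 3 (within the scatter), stayed within it. Compound 2 is held only as a limit, so this step is a bound and its true size remains unfixed: the limit of < 4 in this assay, at which 1 of the 4 values shown sits. Compound 4 gives 5.57 with fluoro as the only substituent on the six-membered aromatic ring, so a measured agonist value on this read-out does not depend on a methoxy group being present on the core.

Still open is whether the gain belongs to fluoro itself or simply to the departure of ethoxycarbonyl, as the compounds shown hold only these two groups at this position and give no series of substituents there to separate the two readings. On these data alone, how a carboxylic acid, an amine or a longer chain at this position would read in this assay, and what methoxy would add alongside fluoro, remain unknown from these compounds.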